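Bis(trifluoromethyl)sulfonamide series: swapping the aryl group on the chain

This account rests on a few compounds, and the source may have more. Where it says the series, first, only, none or still open, it means among the compounds named here.

Compound 2 `O=S(=O)(NCCCNCC1COc2ccccc2O1)c1cc(C(F)(F)F)cc(C(F)(F)F)c1` gives 1200 nM in a functional assay on BXPC-3 cells (Homo sapiens) for inhibition, read by MTT assay, with a stated time of 72 h (a higher number here means a weaker inhibitor of growth, a lower number a stronger inhibitor of growth), the lowest of the three numbers recorded, although compound 1 `COc1cccc(CNCCCNS(=O)(=O)c2cc(C(F)(F)F)cc(C(F)(F)F)c2)c1` with 1700 nM sits within the scatter of it; compound 3 `O=S(=O)(NCCNCc1cccc2ccccc12)c1cc(C(F)(F)F)cc(C(F)(F)F)c1` gives 23000 nM and differs from compound 2 in more than one place, so its value is noted without a step. Compound 4 `O=S(=O)(NCCCNCc1ccc(Br)cc1)c1cc(C(F)(F)F)cc(C(F)(F)F)c1` is the next analogue: 4-bromophenyl in place of 2,3-dihydro-1,4-benzodioxin-2-yl on a saturated chain carbon bound to an amine nitrogen. Among the compounds with values here, the only single-point step at this position, a 1.4-fold lower number from compound 1 to compound 2 (0.15 log units; within the scatter), was within the scatter, so a change of the aryl group here has so far moved little. Compound 4 is therefore expected to land near compound 2, with a 1.3-fold higher number from compound 2 to compound 4 (0.10 log units; within the scatter) as the estimated step and no shift beyond the scatter. The estimate for compound 4 is 1500 nM, in the range 600 nM to 4000 nM.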

Compound 4, concentration for 50% growth inhibition: 1500 nM
For compound 4 middle estimate and measured number coincide at the digits printed, and the stated range covers the measured number.
By their numbers in this assay, from the lowest: compounds 2, 4 and 1 (each within the scatter of the next); then compound 3.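

With 4-bromophenyl at this place, a third group joins the set without a step beyond the scatter in this assay: a 1.3-fold higher number from compound 2 to compound 4 (0.10 log units; within the scatter), and a 1.1-fold lower number from compound 1 to compound 4 (0.05 log units; within the scatter). A group with no hydrogen-bond acceptors and no second ring thus sits within the scatter of the 2,3-dihydro-1,4-benzodioxin-2-yl group, which has both. No supporting data bear on this result.

On these data alone, whether a carboxylic acid or an amine on the phenyl ring would move the number beyond the scatter remains open. Compound 3 differs from the others in more than one place, so its number cannot be assigned to a single change.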